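Amide series on A2780 cells: two limits, one open

This account rests on a few compounds, and the source may have more. Where it says the series, first, only, none or still open, it means among the compounds named here.

Measured so far:
compound 1 `CC(NC(=O)c1cc2cnccc2[nH]1)c1ccc(S(=O)(=O)N2CCCCC2)cc1`: > 10000 nM
compound 2 `O=C(NCc1ccc(S(=O)(=O)c2ccccc2)cc1)c1ccc2nncn2c1`: > 10000 nM

In a functional assay on A2780 cells (Homo sapiens) for inhibition, read by sulforhodamine B assay, with a stated time of 72 h (on this read-out lower numbers stand for stronger inhibition and higher numbers for weaker inhibition), compound 1 gives only a limit, > 10000 nM. In this assay compound 2 likewise gives only a limit, > 10000 nM. Compound 2 thus sits at the limit of > 10000 nM in this assay, at which 2 of the 2 values shown sit, and no number separates the two measured compounds. Compound 3 `O=C(NCc1ccc(S(=O)(=O)c2ccccc2)cc1)c1c[nH]c2ccncc12` differs from compound 2 by a group of 9 heavy atoms (7 carbon, 2 nitrogen; one five-membered aromatic ring with 1 hetero atom, one six-membered aromatic ring with 1 hetero atom) in place of a group of 9 heavy atoms (6 carbon, 3 nitrogen; one five-membered aromatic ring with 3 hetero atoms, one six-membered aromatic ring with 1 hetero atom), on a carbonyl carbon. Going by the values given here, no step between measured compounds exists, so the expectation for compound 3 rests on the two limits alone. The expected step is a number no higher from compound 2 to compound 3 (the limit leaves the size open), none beyond the scatter. Compound 3 is expected at 10000 nM, between 3000 nM and 30000 nM, most probably again reported only as a limit.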

Compound 3, half-maximal inhibitory concentration: 2100 nM
Estimate against measurement, compound 3: 4.8-fold (0.68 log units) above; the measured number lies below the stated range.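

On the carbonyl carbon, the fused ring group with one five-membered aromatic ring with 1 hetero atom, carrying 1 hydrogen-bond donor, gives an at least 4.7-fold lower number from compound 2 to compound 3 (0.67 log units; beyond the scatter) in this assay. This shows that a change at this place alone can bring the read-out off the limit. The full size of the step cannot be read because compound 2 gives only a limit: the limit of > 10000 nM in this assay, at which 2 of the 3 values shown sit.

From the compounds shown here alone, whether the hydrogen-bond donor or the changed ring nitrogens carry the step stays open. Going by these compounds, how a plain phenyl ring or a carboxylic acid would read on this carbonyl carbon also stays open.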